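This account rests on a few compounds, and the source may have more. Where it says the series, first, only, none or still open, it means among the compounds named here.

Measured so far:
compound 1 `COc1cc(-c2cc(/C=C/C(=O)c3ccc(Cl)c(Cl)c3)[nH]n2)cc(OC)c1OC` — 47%
compound 2 `COc1ccc(-c2cc(/C=C/C(=O)c3cc(OC)c(OC)c(OC)c3)[nH]n2)cc1OC` — -43%
compound 3 `COc1ccc(C(=O)/C=C/c2cc(-c3cc(OC)c(OC)c(OC)c3)n[nH]2)cc1` — -69%

All three values come from a functional assay on SW-620 cells (Homo sapiens) for cytotoxicity, read by sulforhodamine B assay, with a stated time of 48 h, tested at 10 uM; a lower number here means a stronger effect, a higher number a weaker effect of the compound at the concentration tested. Compound 3 stands lowest of the three numbers, that is with the strongest effect at the tested concentration; its nearest neighbour is compound 2, whose value is higher by a margin beyond the scatter, and compound 1 sits furthest away, higher still. The single step that links two of these compounds by one change is a number 116 percentage points lower from compound 1 to compound 3 (beyond the scatter), a large move toward stronger effect.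

The next compound, compound 4 `COc1cc(-c2cc(/C=C/C(=O)c3ccc(F)c(F)c3)[nH]n2)cc(OC)c1OC`, returns toward the pattern of compound 1: 3,4-difluorophenyl in place of 4-methoxyphenyl on a carbonyl carbon. Within the data shown here, the one step that bears on this change is the reverse of the measured one, since compound 1 also carries a dihalogenated phenyl on the carbonyl carbon while compound 3 carries the 4-methoxyphenyl. That step, a number 116 percentage points lower from compound 1 to compound 3 (beyond the scatter), was large; the halogens now differ, fluorine in place of chlorine, so a smaller move is plausible, but the direction in this assay is expected to be upward, toward weaker effect. On that basis compound 4 is estimated at 5%, with a range from -45% to 50%, which means an expected step of a number 74 percentage points higher from compound 3 to compound 4 (beyond the scatter).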

Compound 4, a percentage reported as activity, at one concentration (the size of the read-out at that concentration, not a potency): 12%
Beside the measured number, compound 4's estimate is 7 percentage points below it, and the stated range covers the measured number.
By their numbers in this assay, from the lowest: compound 3; then compound 2; then compound 4; then compound 1.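

In this assay, the position on the carbonyl carbon now carries three groups on the same remainder of the molecule, and the second halogenated group also falls well short of 4-methoxyphenyl: 3,4-difluorophenyl in place of 4-methoxyphenyl gives a number 81 percentage points higher from compound 3 to compound 4 (beyond the scatter) and so a weaker effect. The two halogenated groups are not interchangeable either, since 3,4-difluorophenyl in place of 3,4-dichlorophenyl gives a number 35 percentage points lower from compound 1 to compound 4 (beyond the scatter) and so a stronger effect, which means that this position responds to the choice of halogen as well as to the change from methoxy to halogen. No measurement of any property accompanies these values to account for either step.

From the compounds shown here alone, whether the stronger effect of 4-methoxyphenyl extends to a 4-aminophenyl group, a 4-carboxyphenyl group or a phenyl ring with no substituent remains open. Also open, going by these compounds, is whether the order of these three groups holds when the other aryl group of the shared core changes, and each read-out in this assay gives the size of the effect at one concentration rather than a potency.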